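The source may report more compounds than this note shows. Statements on the series, on what has been measured and on what is new or still open speak of the compounds shown alone.

Compound 3 `COc1ccc(Cn2nc(-c3ccccc3)c3cc(C(=N)Nc4cccc(C(F)(F)F)c4)nc(Nc4cc(OC)c(OC)c(OC)c4)c32)cc1` has only "not determined" (no result reported) in a functional assay on PC-3 cells (Homo sapiens) for cytotoxicity, read by MTT assay, with a stated time of 72 h (on this read-out higher numbers stand for weaker inhibition and lower numbers for stronger inhibition), so there is nothing to place it on the scale. Compound 1 `COc1ccc(Cn2nc(-c3ccccc3)c3cc(C(=N)Nc4cccc(C(F)(F)F)c4)nc(NC4CCCCC4)c32)cc1` likewise shows "not determined" (no result reported) there. The only measured point in this set is compound 2 `COc1ccc(Cn2nc(-c3ccccc3)c3cc(C(=N)Nc4ccc(N5CCN(C)CC5)cc4)nc(Nc4cc(OC)c(OC)c(OC)c4)c32)cc1`, which in this assay gives 1240 nM, and compound 2 shares the shared core with compound 3 while differing at more than one place, so it offers only a rough anchor. Compound 4 `COc1ccc(Cn2nc(-c3ccccc3)c3cc(C(=N)Nc4ccccc4)nc(Nc4cc(OC)c(OC)c(OC)c4)c32)cc1` is obtained from compound 3 by hydrogen in place of trifluoromethyl on an aromatic carbon. Going by the values given here, no measured step of this kind exists here, so no direction beyond the usual scatter can be expected from it; the anchor of compound 2 is all that remains. Compound 4 is therefore estimated to fall near 2000 nM, with a likely range from 500 nM to 8000 nM.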

Compound 4, half-maximal inhibitory concentration: 50000 nM
For compound 4 the middle estimate is 25-fold (1.40 log units) below the measured one; the measured number lies above the stated range.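

Going by these compounds alone, on the aromatic ring at the end of the side arm, hydrogen in place of 4-methylpiperazin-1-yl gives a 40-fold higher number from compound 2 to compound 4 (1.61 log units; beyond the scatter) in this assay, the first step that can be read in this set. A higher number here means weaker inhibition, so what this aromatic carbon carries clearly matters to the read-out. No measured evidence accounts for the change.

From the compounds shown here alone, the steps involving compound 1 or compound 3 cannot be read, so the effect of trifluoromethyl stays unknown. Going by these compounds, whether a morpholine ring or a carboxylic acid at this place would behave like 4-methylpiperazin-1-yl also remains open.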